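Chloro for trifluoromethyl applied to compound 3

This account rests on a few compounds, and the source may have more. Where it says the series, first, only, none or still open, it means among the compounds named here.

Measured compounds:
compound 1 `O=C(Nc1cccc(-n2cc(-c3ccncc3)c(-c3cc(O)cc(Cl)c3)n2)c1)Nc1ccc(Cl)c(C(F)(F)F)c1` — in a functional assay on SF-539 cells (Homo sapiens) for inhibition, read by sulforhodamine B assay, with a stated time of 48 h, tested at 100 uM (on this read-out higher numbers stand for a weaker effect at the one concentration tested and lower numbers for a stronger effect), compound 1 gives -50%
compound 2 `O=C(Nc1cccc(-n2cc(-c3ccncc3)c(-c3cc(O)cc(Cl)c3)n2)c1)Nc1ccc(Cl)c(Cl)c1` — in this assay compound 2 gives -52%
compound 3 `COc1cc(Cl)cc(-c2nn(-c3cccc(NC(=O)Nc4ccc(Cl)c(C(F)(F)F)c4)c3)cc2-c2ccncc2)c1` — in this assay compound 3 gives -78%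

Compound 3 stands lowest of the three numbers in this assay; the nearest is compound 2, which lies beyond the scatter from it, and the furthest is compound 1, also beyond the scatter. For the measured compounds named here, the step of a number 28 percentage points lower from compound 1 to compound 3 (beyond the scatter) is the only one of the measured steps that moves the number beyond the scatter. The other measured step, a number 2 percentage points lower from compound 1 to compound 2 (within the scatter), stays within it.

The next compound, compound 4 `COc1cc(Cl)cc(-c2nn(-c3cccc(NC(=O)Nc4ccc(Cl)c(Cl)c4)c3)cc2-c2ccncc2)c1`, differs from compound 3 by chloro in place of trifluoromethyl on an aromatic carbon. This is the same change already seen between compound 1 and compound 2, where it gave a number 2 percentage points lower from compound 1 to compound 2 (within the scatter), a step within the scatter. The step from compound 3 to compound 4 is therefore expected to be small as well, no larger than the scatter: a number 2 percentage points lower from compound 3 to compound 4 (within the scatter). Compound 4 is accordingly estimated at -80% in this assay, with an expected range of -100% to -58%.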

Compound 4, a percentage reported as activity, at one concentration (the size of the read-out at that concentration, not a potency): -40%
The estimate for compound 4 lay 40 percentage points below the measured number, outside the stated range (above it).
By their numbers in this assay, from the lowest: compound 3; then compounds 2, 1 and 4 (each within the scatter of the next, the first and the last beyond it).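

The effect of chloro in place of trifluoromethyl on this aromatic carbon does not carry over between cores: in this assay, with the methyl on the oxygen, the change gives a number 38 percentage points higher from compound 3 to compound 4 (beyond the scatter), and its size depends on the group on that oxygen: the same change on two cores in this assay, a number 2 percentage points lower (within the scatter) from compound 1 to compound 2 and a number 38 percentage points higher (beyond the scatter) from compound 3 to compound 4, 40 percentage points apart, beyond the scatter of two such steps.

The methyl on the oxygen also reverses direction with the group at this position, giving a number 12 percentage points higher from compound 2 to compound 4 (beyond the scatter) when chloro is present: the same change on two cores in this assay, a number 28 percentage points lower (beyond the scatter) from compound 1 to compound 3 and a number 12 percentage points higher (beyond the scatter) from compound 2 to compound 4, 40 percentage points apart, beyond the scatter of two such steps.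

The two changes therefore do not add, and only the pairing of trifluoromethyl with the methyl on the oxygen, in compound 3, gives the lowest number of the four.

As far as these compounds go, whether this dependence extends to bromo or a nitrile at this position, or to an ethyl on the oxygen, stays open. The four compounds give no cause for it.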